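Benzyl group change from compound 2 to compound 3

This account rests on a few compounds, and the source may have more. Where it says the series, first, only, none or still open, it means among the compounds named here.

In a functional assay on Bel-7402 cells (Homo sapiens) for antiproliferative activity, read by MTT assay, with a stated time of 72 h (a lower number here means a stronger inhibitor, a higher number a weaker inhibitor), compound 1 `C=C1C(=O)O[C@H]2[C@H]1CC/C(COC(=O)Cn1cc(F)c(=O)n(Cc3ccc(Cl)cc3)c1=O)=C\CC[C@@]1(C)O[C@@H]21` gives 2560 nM and compound 2 `C=C1C(=O)O[C@H]2[C@H]1CC/C(COC(=O)Cn1cc(F)c(=O)n(Cc3ccc([N+](=O)[O-])cc3)c1=O)=C\CC[C@@]1(C)O[C@@H]21` gives 4070 nM. These two values lie within the scatter of each other, so compound 2 has no distinct rank. Compound 3 `C=C1C(=O)O[C@H]2[C@H]1CC/C(COC(=O)Cn1cc(F)c(=O)n(Cc3ccc(F)c(F)c3)c1=O)=C\CC[C@@]1(C)O[C@@H]21` differs from compound 2 as follows: 3,4-difluorophenyl in place of 4-nitrophenyl on a saturated chain carbon bound to an aromatic nitrogen. Among the measured compounds shown here, the one measured step at this place, a 1.6-fold higher number from compound 1 to compound 2 (0.20 log units; within the scatter), stays within the scatter, and it is the only guide. No change beyond the scatter is therefore expected, and the estimated step is a 1.3-fold lower number from compound 2 to compound 3 (0.10 log units; within the scatter). In this assay, the estimate for compound 3 is 3200 nM, with an expected range of 1300 nM to 8000 nM.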

Compound 3, half-maximal inhibitory concentration: 2700 nM
Compound 3: middle estimate off by 1.2-fold (0.07 log units), on the high side; the measured number falls inside the stated range.
By their numbers in this assay, from the lowest: compounds 1, 3 and 2 (each within the scatter of the next).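

In this assay, 3,4-difluorophenyl in place of 4-nitrophenyl gives a 1.5-fold lower number from compound 2 to compound 3 (0.18 log units; within the scatter), and 3,4-difluorophenyl in place of 4-chlorophenyl gives a 1.1-fold higher number from compound 1 to compound 3 (0.02 log units; within the scatter). On this saturated chain carbon bound to an aromatic nitrogen, the three aryl groups now shown give no step beyond the scatter, and this holds for a ring with two fluorines as well. No measurement at hand bears on why these numbers stay together. On these data alone, whether a benzyl ring carrying an amine or a carboxylic acid, or a longer chain in place of the benzyl group, would give a step beyond the scatter remains open.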